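This account rests on a few compounds, and the source may have more. Where it says the series, first, only, none or still open, it means among the compounds named here.

Measured so far in a functional assay (B cells) with Mus musculus as the target; on this read-out lower numbers stand for an effect already at smaller amounts and higher numbers for an effect only at larger amounts of compound:
compound 1 `COc1ccc(Cn2c(=O)n(C3OC(CO)[C@@H](O)[C@H]3O)c3nc(N)nc(O)c32)cc1` — 135 uM
compound 2 `CCCCn1c(=O)n(C2OC(CO)[C@@H](O)[C@H]2O)c2nc(N)nc(O)c21` — 11 uM
compound 3 `[N-]=[N+]=NCC(O)Cn1c(=O)n(C2OC(CO)[C@@H](O)[C@H]2O)c2nc(N)nc(O)c21` — 39 uM

Compound 3 holds the second highest of the three numbers. Its nearest neighbour is compound 1, reached by a 3.5-fold lower number from compound 1 to compound 3 (0.54 log units; beyond the scatter) going the other way; compound 2 stands furthest, with a 3.5-fold higher number from compound 2 to compound 3 (0.55 log units; beyond the scatter). The widest spread of the set is a 12-fold lower number from compound 1 to compound 2 (1.09 log units; beyond the scatter).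

Compound 4 `Nc1nc(O)c2c(n1)n(C1OC(CO)[C@@H](O)[C@H]1O)c(=O)n2C/C=C/c1ccccc1` is still to be measured. It differs from compound 3 by 2-phenylethenyl in place of 2-azido-1-hydroxyethyl on a saturated chain carbon bound to an aromatic nitrogen.

Within the data shown here, two measured steps bear on this. Among the measured compounds shown here, compound 1, the only member carrying a six-membered aromatic ring of carbon only on the saturated chain carbon bound to the aromatic nitrogen, gives the highest number; compound 2, with a plain propyl free of donors and acceptors, gives the lowest. The 2-phenylethenyl group of compound 4 brings a ring like compound 1 and no donor or acceptor like compound 2, so the expectation for compound 4 in this assay is a number near that of compound 3, with a 1.1-fold lower number from compound 3 to compound 4 (0.05 log units; within the scatter) expected to stay within the scatter or at most modest. The estimate for compound 4 is 35 uM, in the range 8 uM to 150 uM.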

Compound 4, concentration for half-maximal effect: 103 uM
Compound 4: the middle estimate sits 2.9-fold (0.47 log units) below what was measured; the range from low to high includes it.
By their numbers in this assay, from the lowest: compound 2; then compound 3; then compounds 4 and 1 (each within the scatter of the next).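

In this assay the 2-phenylethenyl group has no hydrogen-bond donors or acceptors, like the propyl group, yet it does not keep the number of the propyl member (a 9.4-fold higher number from compound 2 to compound 4 (0.97 log units; beyond the scatter)). The number also rises on going from the 2-azido-1-hydroxyethyl group, which has both donor and acceptors (a 2.6-fold higher number from compound 3 to compound 4 (0.42 log units; beyond the scatter)), so at this position a lack of donors and acceptors does not by itself go with a low number: compound 2 fits that reading and compound 4 goes against it. The two members with a six-membered aromatic ring of carbon only cannot be told apart (a 1.3-fold lower number from compound 1 to compound 4 (0.12 log units; within the scatter)), and nothing at hand explains this link between ring and number.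

Going by these compounds, whether a longer plain chain such as pentyl tracks propyl or the ring-bearing groups stays open. So does the effect of a propyl chain carrying an amine or a carboxylic acid.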